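Hydrazide and hydrazone analogues of a pyridyl oxadiazole thioether

The source may report more compounds than this note shows. Statements on the series, on what has been measured and on what is new or still open speak of the compounds shown alone.

Measured so far:
compound 1 `NNC(=O)CSc1nnc(-c2ccncc2)o1`: 3260 nM
compound 2 `O=C(CSc1nnc(-c2ccncc2)o1)N/N=C/c1ccc(Br)cc1`: 19100 nM

In a functional assay on MCF7 cells (Homo sapiens) for cytotoxicity, read by MTT assay, with a stated time of 48 h (on this read-out lower numbers stand for stronger inhibition and higher numbers for weaker inhibition), compound 1 gives 3260 nM and compound 2 gives 19100 nM. Compound 2 therefore stands at the higher of the two numbers, with compound 1 the nearer and lower one, and the gap between them is beyond the scatter. No stepwise comparison between two measured compounds exists in this set, so no measured step size is available.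

Compound 3 `O=C(CSc1nnc(-c2ccncc2)o1)N/N=C/c1ccccc1[N+](=O)[O-]` is the next analogue: 2-nitrophenyl in place of 4-bromophenyl on a carbon with a double bond to nitrogen. Going by the values given here, there is no measured precedent for this exchange, so the change is expected to stay within the scatter, with at most a slight move towards a lower number. On that basis compound 3 is estimated at 12000 nM, between 4000 nM and 40000 nM, which means an expected step of a 1.6-fold lower number from compound 2 to compound 3 (0.20 log units; within the scatter).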

Compound 3, half-maximal inhibitory concentration: 35600 nM
The estimate for compound 3 lay 3.0-fold (0.47 log units) below the measured number, and the stated range covers the measured number.
By their numbers in this assay, from the lowest: compound 1; then compounds 2 and 3 (each within the scatter of the next).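

In this assay the exchange of 4-bromophenyl for 2-nitrophenyl on a carbon with a double bond to nitrogen gives a 1.9-fold higher number from compound 2 to compound 3 (0.27 log units; within the scatter), so these two groups cannot be told apart at this position. The 2-nitrophenyl group carries hydrogen-bond acceptors and 4-bromophenyl carries none, yet the read-out places no order between compound 2 and compound 3. Nothing measured here speaks to what lies behind this result.

Two aryl groups that also differ in where they carry their substituent cannot show whether the substituent or its place matters more. On these data alone, whether a phenyl ring bearing an amine or a carboxylic acid on the same carbon would read apart from these two also remains open.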